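This account rests on a few compounds, and the source may have more. Where it says the series, first, only, none or still open, it means among the compounds named here.

Compound 1, `COc1ccc(CN(C(C)=O)c2cc(OC)c(OC)c(OC)c2)cc1O`: 160 nM
Compound 2, `C/C=C/C(=O)N(Cc1ccc(OC)c(N)c1)c1cc(OC)c(OC)c(OC)c1`: 310 nM

Of the compounds shown here, two have been measured in a functional assay on KYSE-450 cells (Homo sapiens) for inhibition, read by MTT assay, with a stated time of 48 h; on this read-out higher numbers stand for weaker inhibition and lower numbers for stronger inhibition. Compound 1 gives 160 nM, the lowest of the two numbers, while compound 2 gives 310 nM; the two values lie within the scatter of each other, so no order between them can be claimed. Within the data shown here, compound 2 differs from compound 1 in more than one place, and no single step between them is available.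

The unmeasured compound 3, `C=CC(=O)N(Cc1ccc(OC)c(O)c1)c1cc(OC)c(OC)c(OC)c1`, differs from compound 1 in one place: vinyl in place of methyl on a carbonyl carbon. Since compound 1 and compound 2 stand close together despite their differences in the amide portion, the step from compound 1 to compound 3 is expected to stay within the scatter, with no clear direction. Compound 3 is therefore estimated at 180 nM in this assay, within a range from 60 nM to 550 nM, corresponding to an expected step of a 1.1-fold higher number from compound 1 to compound 3 (0.05 log units; within the scatter).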

Compound 3, half-maximal inhibitory concentration: 160 nM
Compound 3: the middle estimate sits 1.1-fold (0.05 log units) above what was measured, within the range that was stated.
By their numbers in this assay, from the lowest: compounds 1, 3 and 2 (each within the scatter of the next).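

In this assay, replacing methyl with vinyl on a carbonyl carbon whose other neighbour is an amide-type nitrogen gives no change at the digits printed from compound 1 to compound 3 (within the scatter). At this position, then, acetyl and vinylcarbonyl cannot be told apart in this read-out, even with the added carbon and the double bond outside aromatic rings, a single-place comparison that compound 1 and compound 2 could not offer. No evidence is available that bears on this result.

The compounds shown leave open whether a longer chain such as propyl, or a carboxylic acid, on this carbonyl carbon would also leave the value in this assay unchanged. Also open, from the compounds shown here alone, is how an amine in place of the hydroxyl of compound 3 would read with the vinylcarbonyl group kept.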